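A few compounds are considered here, and "the series" means these few. Any claim that something is new, unique, unknown or untested is made for them only; others in the source may bear on it.

Measured in a functional assay on OVCAR-3 cells (Homo sapiens) for inhibition, read by sulforhodamine B assay, with a stated time of 48 h; a lower number here means a stronger inhibitor of growth, a higher number a weaker inhibitor of growth:

- compound 1 `CCOC(=O)c1nn(-c2ccc(Cl)cc2)c(-c2ccc(Cl)cc2)c1CNC(C)(C)C` gives 21600 nM; > 519000 nM (2 entries)
- compound 2 `CC(C)(C)NCc1c(C(=O)O)nn(-c2ccccc2)c1-c1ccc(Cl)cc1` gives > 652000 nM, which is a limit
- compound 3 `CC(C)(C)NCc1c(C(=O)O)nn(-c2ccc(Cl)cc2)c1-c1ccc(F)cc1` gives 116000 nM

Within the data shown here, compound 3, at 116000 nM, is the only compound here whose result is one plain number. Compound 4 `CC(C)(C)NCc1c(C(=O)O)nn(-c2ccc(Cl)cc2)c1-c1ccc(Cl)cc1` has not yet been measured. It differs from compound 3 in a single place: chloro in place of fluoro on an aromatic carbon, para to a large group, so 4-fluorophenyl becomes 4-chlorophenyl. Among the measured compounds shown here, no measured pair here differs in one place only, so the data give no direct guide to this swap. In this assay the expected step is a 1.2-fold lower number from compound 3 to compound 4 (0.06 log units; within the scatter), with no change beyond the usual scatter. For compound 4 the estimate is 100000 nM, with an expected range from 30000 nM to 350000 nM.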

Compound 4, concentration for 50% growth inhibition: 84900 nM
Compound 4: middle estimate off by 1.2-fold (0.07 log units), on the high side; the measured number falls inside the stated range.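

In this assay, among these compounds, the first direct comparison at this position shows a 1.4-fold lower number from compound 3 to compound 4 (0.14 log units; within the scatter) so 4-fluorophenyl and 4-chlorophenyl cannot be told apart here. Chloro in place of hydrogen on an aromatic carbon gives an at least 7.6-fold lower number from compound 2 to compound 4 (0.88 log units; beyond the scatter) and so this second change does move the number beyond the scatter. The value for compound 2 in that step is a limit: the limit of > 652000 nM in this assay, at which 1 of the 4 values shown sits. The compounds shown leave open whether a methoxy group or an amine in place of the halogen at this position would shift the number beyond the scatter.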